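Boc on the amine: second pass in a new core

A few compounds are considered here, and "the series" means these few. Any claim that something is new, unique, unknown or untested is made for them only; others in the source may bear on it.

Compound 1 `CCCCCCCCCCCCCCC(N)CNCCCCC(=O)O` gives 55000 nM in a functional assay on Jurkat cells (Homo sapiens) for inhibition; on this read-out lower numbers stand for stronger inhibition and higher numbers for weaker inhibition. Compound 2 `CCCCCCCCCCCCCCC(CNCCCCC(=O)O)NC(=O)OC(C)(C)C` gives 18000 nM, and the change tert-butoxycarbonyl in place of hydrogen on an amine nitrogen made the step of a 3.1-fold lower number from compound 1 to compound 2 (0.49 log units; beyond the scatter). Compound 3 `CCCCCCCCCCCCCCC(N)CN(CC(=O)OCC)CC(=O)OCC` gives 32000 nM; its value and that of compound 1 lie within the scatter of each other, and the difference between the two cores is not broken down here. Compound 4 `CCCCCCCCCCCCCCC(CN(CC(=O)OCC)CC(=O)OCC)NC(=O)OC(C)(C)C` carries the same change, (tert-butoxycarbonyl in place of hydrogen on an amine nitrogen), on the same kind of place; it is not yet measured in this assay. Within the data shown here, the expectation rests only on the one measured step, from compound 1 to compound 2, which was modest and beyond the scatter; the step from compound 3 to compound 4 is expected to be about a 3.2-fold lower number from compound 3 to compound 4 (0.51 log units; beyond the scatter), since the place is the same. Compound 4 is therefore estimated at 10000 nM, expected between 4000 nM and 25000 nM.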

Compound 4, half-maximal inhibitory concentration: > 60000 nM
Compound 4 was reported as a limit (the forecaster's own chance of this, stated with the estimate: 10%); at least 6.0-fold (0.77 log units) between middle value and limit.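

Compound 4 gives > 60000 nM in this assay, which is a limit of the assay and not a number. From the compounds shown here alone, the step on this core is an at least 1.8-fold higher number from compound 3 to compound 4 (0.27 log units; that floor lies within the scatter), so its true size stays unknown, and a single pair on each core cannot say which feature of the cores sets the difference. Even so, the change does not carry over between the two cores: the same change on two cores in this assay, a 3.1-fold lower number (0.49 log units; beyond the scatter) from compound 1 to compound 2 and an at least 1.8-fold higher number (0.27 log units; that floor lies within the scatter) from compound 3 to compound 4, at least 5.7-fold (0.75 log units) apart, beyond the scatter of two such steps

Still open, going by these compounds, is whether a smaller acyl group on the amine nitrogen, such as acetyl, would follow either core. Also open, on these data alone, is whether a shorter saturated chain in place of the long one would alter the gap between the two steps.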